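A few compounds are considered here, and "the series" means these few. Any claim that something is new, unique, unknown or untested is made for them only; others in the source may bear on it.

Measured compounds in a functional assay on a cell-free system (plasma, Oryctolagus cuniculus) for inhibition, with stated times of 5 min, 1 min and 6 min; on this read-out higher numbers stand for weaker inhibition and lower numbers for stronger inhibition:
compound 1 `CCOC(=O)c1c(C)nc(-c2cccc(C#N)c2)n1OCc1ccccc1` gives 5930 nM
compound 2 `CCOC(=O)c1c(C)nc(-c2cccc(C#N)c2)n1OCc1ccc(C)cc1` gives 6310 nM
compound 3 `Cc1nc(-c2cccc(C#N)c2)n(OCc2ccccc2)c1C(=O)O` gives 6240 nM

Compound 4 `Cc1ccc(COn2c(-c3cccc(C#N)c3)nc(C)c2C(=O)O)cc1` is not yet measured in this assay. Its difference from compound 3 is methyl in place of hydrogen on an aromatic carbon. The same change is made from compound 1 to compound 2, (methyl in place of hydrogen on an aromatic carbon), and it occurs twice among the compounds shown; in this assay it made a step of a 1.1-fold higher number from compound 1 to compound 2 (0.03 log units; within the scatter). The place lines of the two changes read the same word for word, so the two are taken as the same change. Compound 3 and compound 4 carry a core that differs from the core of compound 1 and compound 2 by hydrogen in place of ethyl on an oxygen next to a carbonyl group; that change made a step of a 1.1-fold higher number from compound 1 to compound 3 (0.02 log units; within the scatter). All three measured numbers lie within the scatter of one another, so no order among them is claimed. For compound 4 the step from compound 3 in this assay is expected to be small, a 1.1-fold higher number from compound 3 to compound 4 (0.04 log units; within the scatter), resting on the step of a 1.1-fold higher number from compound 1 to compound 2 (0.03 log units; within the scatter) made by the same change. Compound 4 is therefore estimated at 6800 nM, expected to fall between 3400 nM and 13600 nM.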

Compound 4, half-maximal inhibitory concentration: 6560 nM
The estimate for compound 4 lay 1.0-fold (0.02 log units) above the measured number, and the stated range covers the measured number.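

In this assay, the change from benzyl to 4-methylbenzyl makes a 1.1-fold higher number from compound 3 to compound 4 (0.02 log units; within the scatter), and this step agrees with the one on the other core: the same change on two cores in this assay, a 1.1-fold higher number (0.03 log units; within the scatter) from compound 1 to compound 2 and a 1.1-fold higher number (0.02 log units; within the scatter) from compound 3 to compound 4, 1.0-fold (0.01 log units) apart, within the scatter of two such steps. Hydrogen in place of ethyl on an oxygen next to a carbonyl group makes a 1.0-fold higher number from compound 2 to compound 4 (0.02 log units; within the scatter), and this change also reads alike on both cores: the same change on two cores in this assay, a 1.1-fold higher number (0.02 log units; within the scatter) from compound 1 to compound 3 and a 1.0-fold higher number (0.02 log units; within the scatter) from compound 2 to compound 4, 1.0-fold (0.01 log units) apart, within the scatter of two such steps. Within the data shown here, all of these steps lie within the scatter, so the series shows only that neither change moves the number measurably on either core; it does not show that a step of real size would carry over from one core to another.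

Still open, as far as these compounds go, is whether a methoxy group, a chlorine or a longer chain in place of the methyl on the benzyl group would give a step beyond the scatter. Also open, from the compounds shown here alone, is whether an amide in place of the carboxylic acid or ethyl ester would separate the compounds in this assay.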